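Anilino in Place of Hydroxy on a Double-Bonded Nitrogen

This account rests on a few compounds, and the source may have more. Where it says the series, first, only, none or still open, it means among the compounds named here.

In a functional assay, read by spectrophotometry, with a stated time of 3 min (a lower number here means a stronger inhibitor, a higher number a weaker inhibitor), compound 2 `O=c1cc(/C=N\O)c2c(OCc3ccccc3)cc(OCc3ccccc3)cc2o1` gives 38700 nM as its reading, which lies within the scatter of both other measured compounds. Compound 1 `O=c1cc(/C=N\c2ccc(O)cc2)c2ccc(OCc3ccccc3)cc2o1` gives 64500 nM and compound 3 `O=c1cc(/C=N\O)c2ccc(OCc3ccccc3)cc2o1` gives 22800 nM in the same test, and only these two stand apart by more than the scatter.

The unmeasured compound 4 `O=c1cc(/C=N\Nc2ccccc2)c2c(OCc3ccccc3)cc(OCc3ccccc3)cc2o1` differs from compound 2 by anilino in place of hydroxy on a double-bonded nitrogen and is otherwise the same. For the measured compounds named here, one measured step touches that same nitrogen. It is a 2.8-fold lower number from compound 1 to compound 3 (0.45 log units; beyond the scatter) with hydroxy in place of 4-hydroxyphenyl, so the opposite kind of exchange, with hydroxy leaving, points to a higher number. The other step, a 1.7-fold lower number from compound 2 to compound 3 (0.23 log units; within the scatter) with hydrogen in place of benzyloxy on an aromatic carbon, concerns a different place and says little here. Going by the values given here, no measured compound carries anilino, so this transfer is only loose.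

The expected change is a 2.1-fold higher number from compound 2 to compound 4 (0.32 log units; beyond the scatter) in this assay and so a modest one toward a weaker inhibitor. The estimated value for compound 4 is 80000 nM (expected range 30000 nM to 200000 nM).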

Compound 4, half-maximal inhibitory concentration: 40100 nM
Estimate against measurement, compound 4: 2.0-fold (0.30 log units) above, within the range that was stated.
By their numbers in this assay, from the lowest: compounds 3, 2, 4 and 1 (each within the scatter of the next, the first and the last beyond it).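

In this assay, hydroxy gives way to anilino on the double-bonded nitrogen with a 1.0-fold higher number from compound 2 to compound 4 (0.02 log units; within the scatter), so this position takes up a six-membered aromatic ring of carbon only with no change in the reading beyond the scatter. For the compounds shown here, the one earlier step at this nitrogen, a 2.8-fold lower number from compound 1 to compound 3 (0.45 log units; beyond the scatter), had suggested that replacing hydroxy would go with a weaker inhibitor, but that exchange involved 4-hydroxyphenyl, and the new step shows that this direction does not hold for anilino on the core of compound 2. The compounds offer no measured finding that would explain why the two exchanges at this nitrogen differ.

It remains open whether anilino behaves the same way on the core of compound 3, which carries hydrogen in place of one benzyloxy, since no pair shown tests the exchange on that core. Also open, on these data alone, is how a small methoxy group or a simple amine on the same nitrogen would compare with hydroxy and anilino, or whether a carboxylic acid on the anilino ring would shift the reading.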